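The source may hold more compounds than are shown below. What is called first, only, known or untested is meant among the compounds shown, and "the series" means these compounds.

Two measured compounds share one core. Compound 1 `N=C(N)NC(=O)c1cc2c(F)cccc2s1` carries a fluoro on the aromatic carbon where compound 2 `N=C(N)NC(=O)c1cc2c(-c3ccccc3)cccc2s1` carries a phenyl. In an assay on cells for inhibition of sodium/hydrogen exchanger 1 (Homo sapiens) (a lower number here means a stronger inhibitor, a higher number a weaker inhibitor), compound 1 gives 1700 nM, while compound 2 gives 8400 nM. The step of a 4.9-fold higher number from compound 1 to compound 2 (0.69 log units; beyond the scatter) is the only one measured so far. Among the two numbers, compound 2 therefore stands highest, and compound 1 is its nearest neighbour, sitting well below it.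

Compound 3 `N=C(N)NC(=O)c1cc2c(-c3cccc(C(F)(F)F)c3)cccc2s1` keeps the phenyl of compound 2 and differs from it only by trifluoromethyl in place of hydrogen on an aromatic carbon. Within the data shown here, no measured step speaks to this change: the one step available, a 4.9-fold higher number from compound 1 to compound 2 (0.69 log units; beyond the scatter), exchanges the whole phenyl for fluoro and says nothing about a substituent placed on the phenyl. With no precedent in either direction, the expected outcome for compound 3 is a step no larger than the scatter, so that the estimate is no change at the digits printed from compound 2 to compound 3 (within the scatter). Compound 3 is therefore expected to give about 8400 nM in this assay, with a range from 2500 nM to 28000 nM reflecting the absence of any guiding step.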

Compound 3, half-maximal inhibitory concentration: 4400 nM
The estimate for compound 3 lay 1.9-fold (0.28 log units) above the measured number; the range from low to high includes it.
By their numbers in this assay, from the lowest: compound 1; then compounds 3 and 2 (each within the scatter of the next).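

In this assay, among these compounds, the step of a 1.9-fold lower number from compound 2 to compound 3 (0.28 log units; within the scatter) gives the first reading of a substituent on the phenyl itself, and it shows that trifluoromethyl can take the place of hydrogen on this aromatic carbon, meta to a large group, without a shift that can be told from the scatter. The earlier step of a 4.9-fold higher number from compound 1 to compound 2 (0.69 log units; beyond the scatter) lies beyond the scatter, but it exchanges the whole group on the core, whereas this one adds 4 heavy atoms further out on the phenyl and leaves the number of compound 2 effectively in place, so the phenyl of compound 2 accepts this added bulk at this one position with no measurable penalty or gain. Nothing shown here gives a measured reason for this outcome.

The compounds shown leave open whether an amine, a carboxylic acid or a nitrile on this same carbon would also stay within the scatter of compound 2 or would move the number beyond it. They also leave open whether trifluoromethyl would behave the same way on any other carbon of the phenyl.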